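Amide nitrogen substitution and whole-animal inhibition

This account rests on a few compounds, and the source may have more. Where it says the series, first, only, none or still open, it means among the compounds named here.

Compound 2 `CN(C)C(=O)[C@@H]1CN[C@H](C(=O)N2CCC[C@H]2C#N)C1` stands highest of the two numbers in an assay on the whole organism (plasma, strain Sprague-Dawley) for inhibition of Dipeptidyl peptidase 4 (Rattus norvegicus), with a stated time of 10 h, at a dose of 1 mg/kg by the oral route (on this read-out higher numbers stand for more inhibition at the one dose given (going by the name of the read-out) and lower numbers for less inhibition), giving 52%. For the measured compounds named here, its nearest neighbour is compound 1 `N#C[C@@H]1CCCN1C(=O)[C@@H]1C[C@H](C(N)=O)CN1`, which in this assay gives 20%; the one single-place step measured so far, a number 32 percentage points higher from compound 1 to compound 2 (beyond the scatter), is dimethylamino in place of amino on a carbonyl carbon. Compound 3 `CNC(=O)[C@@H]1CN[C@H](C(=O)N2CCC[C@H]2C#N)C1` is not yet measured; it differs from compound 2 by hydrogen in place of methyl on an amide-type nitrogen, so the amide-type nitrogen bears hydrogen where compound 2 bears methyl. This partly reverses the measured step, which ran beyond the scatter in favour of the dimethylcarbamoyl group. Compound 3 is therefore expected to give back part of that gain, the expected step being a number 14 percentage points lower from compound 2 to compound 3 (beyond the scatter). For compound 3 the estimate in this assay is 38%, with a range of 22% to 54%.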

Compound 3, a percentage reported as inhibition, in the whole organism at one dose (the size of the read-out at that dose, not a potency): 28%
For compound 3 the middle estimate is 10 percentage points above the measured one, within the range that was stated.
By their numbers in this assay, from the lowest: compounds 1 and 3 (each within the scatter of the next); then compound 2.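

In this assay, the single methyl on the amide-type nitrogen gives a number 8 percentage points higher from compound 1 to compound 3 (within the scatter), whereas removing the second methyl gives a number 24 percentage points lower from compound 2 to compound 3 (beyond the scatter). Among these three compounds, the first methyl therefore brings no step that can be read beyond the scatter, and only the full dimethylcarbamoyl group of compound 2 stands apart from both the carbamoyl and methylcarbamoyl compounds. No available evidence accounts for this uneven response to methyl substitution.

The compounds shown leave open whether a diethylamino group, or a carboxylic acid in place of the amide, would match or exceed the number of compound 2. With one dose and one stated time, these numbers also leave open how the three compounds would compare at other doses or times.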